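This account rests on a few compounds, and the source may have more. Where it says the series, first, only, none or still open, it means among the compounds named here.

Three related compounds have been tested in an assay on RAW264.7 cells for antagonist activity at Toll-like receptor 2 (Mus musculus), read by Griess assay, with a stated time of 24 h; on this read-out higher numbers stand for weaker inhibition and lower numbers for stronger inhibition. Compound 1 `C=CCCCSC[C@H](N)C(=O)OC` gives 31300 nM in this assay. Compound 2 `COC(=O)[C@@H](N)CSCc1ccc(F)cc1` gives 99600 nM in this assay. Compound 3 `C=CCSC[C@H](NC(=O)c1cc(OC)c(OC)c(OC)c1)C(=O)OC` gives 49300 nM in this assay. Among these three numbers compound 3 stands second highest: the number of compound 1 lies within the usual scatter of repeated measurements around it, so no order between these two can be claimed, whereas the number of compound 2 lies beyond the scatter on the higher side, which on this read-out means weaker inhibition by compound 2.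

Compound 4 `C#CCSC[C@H](NC(=O)c1cc(OC)c(OC)c(OC)c1)C(=O)OC` has not yet been measured in this assay. It differs from compound 3 in one place: ethynyl in place of vinyl on a saturated chain carbon bound to a sulfur. The rest of the molecule is unchanged.

Going by the values given here, no pair of measured compounds shows this kind of change, so the data give no direct guide to its size or direction. The change is small, and a shift beyond the scatter in either direction is not expected. The estimate for compound 4 is 45000 nM, with a range from 20000 nM to 100000 nM. The step from compound 3 to compound 4 that this estimate means, a 1.1-fold lower number from compound 3 to compound 4 (0.04 log units; within the scatter), is expected to stay within the scatter.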

Compound 4, half-maximal inhibitory concentration: 53200 nM
Estimate against measurement, compound 4: 1.2-fold (0.07 log units) below; the range from low to high includes it.
By their numbers in this assay, from the lowest: compounds 1, 3, 4 and 2 (each within the scatter of the next, the first and the last beyond it).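

In this assay the swap of vinyl for ethynyl on a saturated chain carbon bound to a sulfur, which turns allylsulfanyl into propargylsulfanyl, gives a 1.1-fold higher number from compound 3 to compound 4 (0.03 log units; within the scatter) and so allows no claim of order between the two compounds. Going by these compounds alone, this is the first direct reading of any single change, since the earlier compounds differ from one another in more than one place and could only be set side by side loosely. It shows that on this shared core, a double bond and a triple bond at this place, in groups with the same count of heavy atoms, cannot be told apart by this read-out, though the data offer no explanation for that.

From the compounds shown here alone, what stays open is whether this place responds at all to a larger change, such as a longer chain, an amine or a carboxylic acid in place of the ethynyl. A single pair also cannot show whether the same swap would read alike on a different core, so the result holds only for these two compounds.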